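The source may hold more compounds than are shown below. What is called first, only, known or untested is meant among the compounds shown, and "the series" means these compounds.

Measured in a toxicity assay on Vero cells (Chlorocebus sabaeus) for inhibition; a lower number here means that less compound is needed, a higher number that more compound is needed for the effect:
Compound 1 `COc1cccc(NC(=O)c2nnn(Cc3ccc([S+](C)[O-])cc3)c2N)c1`: > 50100 nM (a limit)
Compound 2 `COc1cccc(NC(=O)c2nnn(Cc3ccc(C(C)C)cc3)c2N)c1`: > 50100 nM (a limit)
Compound 3 `COc1cccc(NC(=O)c2nnn(Cc3ccccc3)c2N)c1`: > 50100 nM (a limit)

Compound 3 gives > 50100 nM, which is a limit of the assay and not a number. The whole set so far stands at the same place: the limit of > 50100 nM in this assay, at which 3 of the 3 values shown sit. Going by the values given here, no measured compound therefore has an actual number to start from.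

Compound 4 `COc1cccc(NC(=O)c2nnn(Cc3ccc(-n4cccn4)cc3)c2N)c1` differs from compound 3 in one place: 1H-pyrazol-1-yl in place of hydrogen on an aromatic carbon. Put simply, 1H-pyrazol-1-yl stands in place of hydrogen on an aromatic carbon.

Three measured steps swap the group at such a carbon: a step that the two limits leave unreadable from compound 2 to compound 3, a step that the two limits leave unreadable from compound 1 to compound 3 and a step that the two limits leave unreadable from compound 1 to compound 2. These three steps offer neither a size nor a direction to carry over. No step beyond the scatter is therefore expected in this assay. This expectation is a loose one, since none of the groups measured at that carbon holds a ring of its own.

The expected change is a step that the limit leaves unreadable from compound 3 to compound 4. For compound 4 the estimated value is 60000 nM, with an expected range from 30000 nM to 120000 nM, and a report of only a limit is the likeliest outcome.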

Compound 4, half-maximal effective concentration: > 50100 nM
Compound 4: only a limit was reported; the forecaster's own chance of this, stated with the estimate: 85%; the middle value is on the limit's open side.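

In this assay, going by these compounds alone, compound 4 gives > 50100 nM, which is a limit and not a number, and no step to compound 4 from compound 1, compound 2 or compound 3 can be read. The compounds shown leave open how much of each is needed for the effect in this assay, and whether the group on that aromatic carbon changes this amount at all: the limit of > 50100 nM in this assay, at which 4 of the 4 values shown sit.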